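This account rests on a few compounds, and the source may have more. Where it says the series, first, only, none or still open, it means among the compounds named here.

Compound 1 `C=C(Br)C(=O)Nc1cccc(-c2cn3nc(-c4ccc(OCC)cc4)sc3n2)c1` and compound 2 `C=C(Br)C(=O)Nc1cccc(-c2cn3nc(Cc4ccc(Cl)cc4)sc3n2)c1` share the same core; in a functional assay on FM3A cells (Mus musculus) for inhibition, read by cell counting, with a stated time of 2 days (on this read-out higher numbers stand for weaker inhibition and lower numbers for stronger inhibition), compound 1 gives 1100 nM and compound 2 gives 1100 nM. The step of no change at the digits printed from compound 1 to compound 2 (within the scatter) shows that swapping the aryl group on the five-membered ring left the read-out level. Compound 3 `C=C(Br)C(=O)Nc1cccc(-c2cn3nc(-c4cccc(OC)c4)sc3n2)c1` carries the change (3-methoxyphenyl in place of 4-chlorobenzyl on an aromatic carbon). Going by the values given here, the only measured step that bears on this, from compound 1 to compound 2, lay within the scatter, so the expected step is no change at the digits printed from compound 2 to compound 3 (within the scatter), none beyond the scatter. Compound 3 is therefore estimated at 1100 nM, with a range from 500 nM to 2500 nM.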

Compound 3, half-maximal inhibitory concentration: 500 nM
For compound 3 the middle estimate is 2.2-fold (0.34 log units) above the measured one, and the stated range covers the measured number.
By their numbers in this assay, from the lowest: compound 3; then compounds 1 and 2 (each within the scatter of the next).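

In this assay 3-methoxyphenyl on this aromatic carbon gives a 2.2-fold lower number from compound 2 to compound 3 (0.34 log units; beyond the scatter) and a 2.2-fold lower number from compound 1 to compound 3 (0.34 log units; beyond the scatter) as modest steps beyond the scatter. The position therefore responds to the choice of group, which the level pair of compound 1 and compound 2 did not show. No available measurement accounts for this difference. The step from 4-ethoxyphenyl changes both the ether chain and its place on the phenyl ring, and these two changes cannot be separated here. Going by these compounds, how an amine or a carboxylic acid in place of the methoxy group would read remains open.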